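The compounds below may be only part of what the source reports. "The series", "measured", "known", "first", "only" and "open" are said of these compounds alone.

Compound 1, `O=C(Nc1cccc(-n2cc(-c3ccncc3)c(-c3ccc(Cl)c(O)c3)n2)c1)Nc1ccc(Cl)c(Cl)c1`, stands highest of the two numbers measured in a functional assay on SR cells (Homo sapiens) for inhibition, read by sulforhodamine B assay, with a stated time of 48 h (on this read-out higher numbers stand for weaker inhibition of growth and lower numbers for stronger inhibition of growth), where compound 1 gives 1140 nM. Compound 2, `COc1cc(-c2nn(-c3cccc(NC(=O)c4ccccc4)c3)cc2-c2ccncc2)ccc1Cl`, gives 250 nM in this assay, a lower number that lies beyond the usual scatter. Compound 3, `O=C(Nc1cccc(-n2cc(-c3ccncc3)c(-c3ccc(Cl)c(O)c3)n2)c1)Nc1ccc(Cl)c(C(F)(F)F)c1`, differs from compound 1 in one place: trifluoromethyl in place of chloro on an aromatic carbon. Among the measured compounds shown here, no measured pair shows this exact change, so its effect here is untested; the expected step of a 1.3-fold lower number from compound 1 to compound 3 (0.13 log units; within the scatter) is small, probably within the scatter. For compound 3 the estimated number is 850 nM, with a range from 300 nM to 2500 nM.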

Compound 3, concentration for 50% growth inhibition: 715 nM
Estimate against measurement, compound 3: 1.2-fold (0.08 log units) above; the range from low to high includes it.
By their numbers in this assay, from the lowest: compound 2; then compounds 3 and 1 (each within the scatter of the next).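

Putting trifluoromethyl in place of chloro, on the ring that turns 3,4-dichlorophenyl into 4-chloro-3-(trifluoromethyl)phenyl, gives a 1.6-fold lower number from compound 1 to compound 3 (0.20 log units; within the scatter) in this assay. In this single pair, then, the position holds a group of four heavy atoms in place of one, with no difference that stands clear of the scatter. No measurement shown here bears on why the step is this small. On these data alone, whether an amine or a nitrile at this place would give a step beyond the scatter remains open. So does whether the same swap would read alike on a different core.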